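One ring exchanged on the chain of compound 2

The compounds below may be only part of what the source reports. "The series", "measured", "known", "first", "only" and "open" are said of these compounds alone.

Of the compounds shown here, three sharing a core have been tested in a functional assay on RAW264.7 cells (Mus musculus) for inhibition, read by Griess assay, with stated times of 2 h and 18 h; a higher number here means a weaker inhibitor, a lower number a stronger inhibitor. Compound 1 (`CC(=O)O[C@@H]1CC[C@@]2(C)[C@@H](C(=O)[C@H](O)[C@@H](C)[C@]2(O)CCc2ccoc2)C1(C)C`) reached only the assay limit, > 50000 nM, which is a limit and not a number. Compound 2 (`CCOC1CC(O)(CCC2=C(C)C(=O)C(O)=C3C(C)(C)[C@H](OC(C)=O)CC[C@]23C)CO1`) gives 21700 nM and compound 3 (`CCOC1CC(O)(CCC2=C(C)C(=O)[C@@H](O)[C@H]3C(C)(C)[C@H](OC(C)=O)CC[C@]23C)CO1`) gives 30400 nM. Among the measured compounds shown here, these two values lie within the scatter of each other, and they are the only actual numbers in the set.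

Compound 4 (`COC1C=C(CCC2=C(C)C(=O)C(O)=C3C(C)(C)[C@H](OC(C)=O)CC[C@]23C)C(=O)O1`) has not yet been measured in this assay. On a saturated chain carbon, two bonds along the chain from a double-bonded ring carbon, it loses the 5-ethoxy-3-hydroxyoxolan-3-yl group of compound 2 and carries a different five-membered non-aromatic ring (a group of 8 heavy atoms (5 carbon, 3 oxygen; one five-membered non-aromatic ring with 1 hetero atom) in place of a group of 9 heavy atoms (6 carbon, 3 oxygen; one five-membered non-aromatic ring with 1 hetero atom), on a saturated chain carbon, two bonds along the chain from a double-bonded ring carbon). For the measured compounds named here, no measured pair in the set shows a change at this place, so the expectation starts from compound 2 at 21700 nM. The expected 1.1-fold lower number from compound 2 to compound 4 (0.04 log units; within the scatter) stays within the scatter, with no direction foreseen. For compound 4 the estimated value is 20000 nM, with an expected range of 7000 nM to 50000 nM.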

Compound 4, half-maximal inhibitory concentration: 40800 nM
For compound 4 the middle estimate is 2.0-fold (0.31 log units) below the measured one; the measured number falls inside the stated range.
By their numbers in this assay, from the lowest: compounds 2, 3 and 4 (each within the scatter of the next). At a limit, above all of these: compound 1.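

In this assay, the exchange of the 5-ethoxy-3-hydroxyoxolan-3-yl group for the new five-membered ring gives the first step read at this place: a 1.9-fold higher number from compound 2 to compound 4 (0.27 log units; within the scatter). The hydrogen-bond donor counted on the leaving group is absent from the entering ring, yet compound 2 and compound 4 remain within the scatter of each other, so this exchange shows no separation between them. Compound 1 stays a limit and not a number, and steps to it cannot be read: the limit of > 50000 nM in this assay, at which 1 of the 4 values shown sits.

The compounds shown leave open whether any group on this saturated chain carbon can separate from compound 2 beyond the scatter. An amine, a carboxylic acid or a longer chain at this place would be needed to tell, and the role of the ring itself remains unresolved.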